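Ethyl in Place of Amino on the Amide Nitrogen

The compounds below may be only part of what the source reports. "The series", "measured", "known", "first", "only" and "open" are said of these compounds alone.

Of the compounds shown here, three sharing one core have been tested in a functional assay on HEK293 cells for agonist activity at lutropin-choriogonadotropic hormone receptor (Homo sapiens), read by cAMP accumulation; on this read-out higher numbers stand for larger maximal responses and lower numbers for smaller maximal responses. Compound 1 `COc1cccc(-c2nc(SC)nc3sc(C(=O)NNC(C)(C)C)c(N)c23)c1` gives 6%. Compound 2 `COc1cccc(-c2nc(SC)nc3sc(C(=O)NCC#N)c(N)c23)c1`, which carries cyanomethyl on the amide-type nitrogen, gives 20.3%, and the change was a number 14.3 percentage points higher from compound 1 to compound 2 (beyond the scatter). Compound 3 `COc1cccc(-c2nc(SC)nc3sc(C(=O)NN)c(N)c23)c1` gives 8.5%. Compound 3 stands second highest of the three numbers: the step is a number 2.5 percentage points higher from compound 1 to compound 3 (within the scatter), so the two cannot be told apart, while compound 2 sits clearly above it, with a number 11.8 percentage points lower from compound 2 to compound 3 (beyond the scatter).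

Compound 4 `CCNC(=O)c1sc2nc(SC)nc(-c3cccc(OC)c3)c2c1N` has not yet been measured. It differs from compound 3 in one place: ethyl in place of amino on an amide-type nitrogen. For the measured compounds named here, no measured step swaps amino for ethyl directly. The nearest guide is that a small carbon chain on this nitrogen, in compound 2, gave the highest response, whereas with nitrogen-bearing groups on this nitrogen compound 1 gave 6% and compound 3 gave 8.5%. A modest rise in this assay is therefore expected, though it may well stay within the scatter. The step expected for compound 4 is a number 5.5 percentage points higher from compound 3 to compound 4 (within the scatter). Compound 4 is estimated at 14%, with a range from 5% to 28%.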

Compound 4, largest response reached (reported as efficacy), in percent of the reference or control that the assay uses: 26.9%
Compound 4: middle estimate off by 12.9 percentage points, on the low side, within the range that was stated.
By their numbers in this assay, from the lowest: compounds 1 and 3 (each within the scatter of the next); then compounds 2 and 4 (each within the scatter of the next).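

In this assay, ethyl on the amide-type nitrogen stands clearly above the amino group, with a number 18.4 percentage points higher from compound 3 to compound 4 (beyond the scatter), and clearly above the (tert-butyl)amino group, with a number 20.9 percentage points higher from compound 1 to compound 4 (beyond the scatter), so this nitrogen tolerates a simple carbon chain and the response there can be raised by a single change. Ethyl and cyanomethyl cannot be told apart, with a number 6.6 percentage points higher from compound 2 to compound 4 (within the scatter), which shows that the nitrile of compound 2 is not required for its response, since a plain methyl at that chain carbon does as well within the scatter. Across these four compounds, the two with a carbon group on this nitrogen, compound 2 and compound 4, form the upper pair, the two with a nitrogen group, compound 1 and compound 3, form the lower pair, and no compound goes against that split.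

From the compounds shown here alone, whether the response keeps rising with a longer chain such as propyl or butyl, or holds with a methyl or a cyclopropyl group on this nitrogen, remains open. The compounds shown also give no measurement that explains why carbon groups here outperform nitrogen groups.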